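Swapping the amide aryl group on a flavonol scaffold

This account rests on a few compounds, and the source may have more. Where it says the series, first, only, none or still open, it means among the compounds named here.

Measured compounds:
- Compound 1, `O=C(Nc1cccc(-c2oc3cc(-c4ccc(F)cc4)ccc3c(=O)c2O)c1)c1ccc(C(F)(F)F)cc1`: 29400 nM
- Compound 2, `COc1cccc(C(=O)Nc2cccc(-c3oc4cc(-c5ccc(F)cc5)ccc4c(=O)c3O)c2)c1`: 9160 nM
- Compound 3, `Cc1cc(C(=O)Nc2cccc(-c3oc4cc(-c5ccc(F)cc5)ccc4c(=O)c3O)c2)ccc1F`: 7440 nM

All three share one core and differ only in the aryl group attached to the amide carbonyl. In a functional assay on MDA-MB-231 cells (Homo sapiens) for antiproliferative activity, read by CCK-8 assay, with a stated time of 72 h (on this read-out higher numbers stand for weaker inhibition and lower numbers for stronger inhibition), compound 3 gives the lowest of the three numbers, but its gap to compound 2 is within the scatter, so the two cannot be told apart; only compound 1 sits clearly apart, as the step of a 4.0-fold lower number from compound 1 to compound 3 (0.60 log units; beyond the scatter) shows.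

Compound 4, `COc1cc(OC)cc(C(=O)Nc2cccc(-c3oc4cc(-c5ccc(F)cc5)ccc4c(=O)c3O)c2)c1`, has not yet been measured. It differs from compound 3 in one place: 3,5-dimethoxyphenyl in place of 4-fluoro-3-methylphenyl on a carbonyl carbon.

Among the measured compounds shown here, two measured steps bear on this change. Introducing a methoxy-bearing aryl, as in a 3.2-fold lower number from compound 1 to compound 2 (0.51 log units; beyond the scatter), gave a modest move toward stronger inhibition, while a 1.2-fold lower number from compound 2 to compound 3 (0.09 log units; within the scatter) stayed within the scatter. For the measured compounds named here, a second methoxy group has no precedent here, so no step beyond the scatter is expected in this assay.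

Compound 4 is therefore expected to give about 8000 nM, within 3000 nM to 20000 nM, a step of a 1.1-fold higher number from compound 3 to compound 4 (0.03 log units; within the scatter) that is expected to stay within the scatter.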

Compound 4, half-maximal inhibitory concentration: 4040 nM
Beside the measured number, compound 4's estimate is 2.0-fold (0.30 log units) above it; the measured number falls inside the stated range.
By their numbers in this assay, from the lowest: compounds 4, 3 and 2 (each within the scatter of the next, the first and the last beyond it); then compound 1.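

In this assay, among the compounds shown here, the step of a 2.3-fold lower number from compound 2 to compound 4 (0.36 log units; beyond the scatter) is the first to isolate a single methoxy group, placed on an aromatic carbon of the amide aryl group, whereas the earlier steps exchanged whole aryl groups. The 3,5-dimethoxyphenyl and 4-fluoro-3-methylphenyl groups cannot be told apart, as the step of a 1.8-fold lower number from compound 3 to compound 4 (0.27 log units; within the scatter) shows, yet the step of a 7.3-fold lower number from compound 1 to compound 4 (0.86 log units; beyond the scatter) puts clear distance between the 3,5-dimethoxyphenyl and 4-(trifluoromethyl)phenyl groups. Nothing given here explains why these aryl groups differ in this way.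

Going by these compounds, it remains open whether a third methoxy group, or an ethoxy group in place of each methoxy, would lower the number further. Also open, on these data alone, is how an amine or a carboxylic acid on this aryl ring would compare.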